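Removing the ethoxy group from compound 3

The compounds below may be only part of what the source reports. "The series", "measured", "known", "first", "only" and "open" are said of these compounds alone.

For the measured compounds named here, in a functional assay on K562 cells (Homo sapiens) for antiproliferative activity, read by MTT assay, with a stated time of 72 h (on this read-out higher numbers stand for weaker inhibition and lower numbers for stronger inhibition), compound 3 (`CCOc1ccc(-c2ncnn2-c2cc(OC)c(OC)c(OC)c2)cc1`) gives 20 nM as the only true number so far. Compound 1 (`COc1cc(-n2ncnc2-c2ccc(C)cc2)cc(OC)c1OC`) gives > 10000 nM as a limit of the assay. Compound 2 (`COc1cc(-n2ncnc2-c2ccc(Cl)c(Cl)c2)cc(OC)c1OC`) gives > 10000 nM as a limit of the assay too.

The next structure, compound 4 (`COc1cc(-n2ncnc2-c2ccccc2)cc(OC)c1OC`), has hydrogen in place of ethoxy on an aromatic carbon, para to a large group (hydrogen in place of ethoxy on an aromatic carbon).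

Two measured steps are available. Ethoxy in place of methyl on an aromatic carbon gave an at least 500-fold lower number from compound 1 to compound 3 (2.69 log units; beyond the scatter) and is the closest guide, since it also turns on the ethoxy group. The change to 3,4-dichlorophenyl in place of 4-methylphenyl gave a step that the two limits leave unreadable from compound 1 to compound 2 and so offers no size to work with.

Compound 4 keeps the shared core but has no ethoxy group, so it is expected to behave more like compound 1 than like compound 3. A large step toward weaker inhibition is therefore expected, estimated as a 400-fold higher number from compound 3 to compound 4 (2.60 log units; beyond the scatter) in this assay and possibly ending at the limit of the assay. Compound 4 is estimated at 8000 nM with an expected range from 1500 nM to 20000 nM in this assay for now.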

Compound 4, half-maximal inhibitory concentration: > 10000 nM
Compound 4 ended at the assay's limit; the forecaster's own chance of this, stated with the estimate: 65%; at least 1.2-fold (0.09 log units) between middle value and limit.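

In this assay, taking the ethoxy group away from this aromatic carbon, para to a large group, gives an at least 500-fold higher number from compound 3 to compound 4 (2.69 log units; beyond the scatter). Until now ethoxy had been set against methyl alone at this place; with hydrogen there as well, the low number of compound 3 is tied to the ethoxy group itself, and neither of the two smaller substituents shown restores it. The steps among compound 1, compound 2 and compound 4 cannot be read, so no order among hydrogen, methyl and the 3,4-dichlorophenyl change can be drawn, and the series so far holds a single true number against a shared ceiling: the limit of > 10000 nM in this assay, at which 3 of the 4 values shown sit.

Open, from the compounds shown here alone, is whether a methoxy group at this place, a longer chain such as propoxy, or an amine would keep the number low, and how far the chain can grow before the number rises. The compounds shown also do not separate the oxygen of the ethoxy group from its two carbons as the part that carries the step.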